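Fluoro added to the fluorophenyl of a piperazine aminothiophene

The compounds below may be only part of what the source reports. "The series", "measured", "known", "first", "only" and "open" are said of these compounds alone.

Compound 1 `Nc1scc(CN2CCN(c3ccccc3C(F)(F)F)CC2)c1C(=O)c1ccc(Cl)cc1` and compound 2 `Nc1scc(CN2CCN(c3ccccc3F)CC2)c1C(=O)c1ccc(Cl)cc1` share one core and differ only in the substituent on the phenyl attached to the piperazine. In a functional assay on CHO cells with adenosine receptor A1 (Homo sapiens) as the target, read by cAMP accumulation and immunoassay, with a stated time of 6 min, tested at 0.01 uM (on this read-out lower numbers stand for a stronger effect and higher numbers for a weaker effect at the one concentration tested), compound 1 gives 0%, and in this assay compound 2 gives 2.1%. Among the measured compounds shown here, the one step measured so far, a number 2.1 percentage points higher from compound 1 to compound 2 (within the scatter), changes nothing beyond the scatter, so compound 2 and compound 1 stand together at the floor of this read-out and neither can be called the more active.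

Compound 3 `Nc1scc(CN2CCN(c3ccc(F)cc3F)CC2)c1C(=O)c1ccc(Cl)cc1` carries the difference (fluoro in place of hydrogen on an aromatic carbon). For the measured compounds named here, no measured step adds a fluoro to this phenyl; the only step available, a number 2.1 percentage points higher from compound 1 to compound 2 (within the scatter), concerns an exchange on the same ring and was within the scatter. Both measured compounds sit near zero, which leaves little room for a fall and gives no indication of a rise.

For compound 3 the expected step in this assay is therefore a number 0.1 percentage points lower from compound 2 to compound 3 (within the scatter), nothing beyond the scatter. Compound 3 is estimated at 2% in this assay, with a range from -8% to 12%.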

Compound 3, a percentage reported as activity, at one concentration (the size of the read-out at that concentration, not a potency): 0%
Compound 3: the middle estimate sits 2 percentage points above what was measured; the measured number falls inside the stated range.
By their numbers in this assay, from the lowest: compounds 1, 3 and 2 (each within the scatter of the next).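

In this assay, the first substitution at this ring carbon, para to a large group and meta to a fluoro group, reads a number 2.1 percentage points lower from compound 2 to compound 3 (within the scatter): a fluoro in place of hydrogen here leaves the read-out within the scatter, and the position accepts this added atom without a measurable difference. The exchange of the whole aryl group, 2,4-difluorophenyl in place of 2-(trifluoromethyl)phenyl, reads no change at the digits printed from compound 1 to compound 3 (within the scatter), so the three substitution patterns on this phenyl cannot be separated at the single concentration tested, and all three numbers lie near the bottom of the read-out, where a further fall has little room to show. Nothing measured alongside these numbers accounts for this flat result.

Still open, going by these compounds, is whether a larger or differently charged group at this same position, such as methoxy, an amine or a carboxylic acid, would move the number beyond the scatter. Also open, on these data alone, is whether compound 1, compound 2 and compound 3 would separate at lower concentrations, since one concentration gives the size of the read-out and not a potency.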